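Side-chain swap from compound 1 to compound 3

The compounds below may be only part of what the source reports. "The series", "measured", "known", "first", "only" and "open" are said of these compounds alone.

Compound 1 `O=C(NCc1cc(Cl)ccc1-n1cnnn1)[C@@H]1C[C@@H]2C[C@@H]2N1C(=O)[C@H](O)Cc1ccccn1` is the only fully numbered point in the series: in an ADME assay on liver for metabolic stability, with Liver microsome (Homo sapiens) as the target, read by LC-MS, using microsomes (a lower number here means slower removal, a higher number faster removal of the compound), compound 1 gives 17 mL.min-1.g-1. Compound 2 `O=C(NCc1cc(Cl)ccc1-n1cnnn1)[C@@H]1CCON1C(=O)[C@H](O)c1ccccc1` reaches only a limit of the assay, < 12 mL.min-1.g-1. Compound 3 `CC(C)(C)OC[C@@H](O)C(=O)N1[C@H](C(=O)NCc2cc(Cl)ccc2-n2cnnn2)C[C@@H]2C[C@@H]21` differs from compound 1 by tert-butoxy in place of pyridin-2-yl on a saturated chain carbon, two bonds along the chain from a carbonyl carbon and an oxygen on a saturated carbon. Among the measured compounds shown here, no measured pair of this kind is in hand, so the expected step of a 1.5-fold higher number from compound 1 to compound 3 (0.17 log units; within the scatter) in this assay is a modest rise, close to the edge of the usual scatter. Compound 3 is accordingly estimated at 25 mL.min-1.g-1, with a range from 10 mL.min-1.g-1 to 60 mL.min-1.g-1.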

Compound 3, intrinsic clearance in microsomes: 21 mL.min-1.g-1
For compound 3 the middle estimate is 1.2-fold (0.08 log units) above the measured one; the range from low to high includes it.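

Among the compounds shown here, this is the first one-place comparison, and in this assay it gives a 1.2-fold higher number from compound 1 to compound 3 (0.09 log units; within the scatter), so the two compounds cannot be told apart. At this saturated chain carbon, for this pair, the read-out does not depend on keeping the aromatic ring of pyridin-2-yl, since the ringless tert-butoxy serves equally. Nothing in hand explains this result.

From the compounds shown here alone, what an amine, a carboxylic acid or a longer chain would give at this place remains open. So does whether the same swap behaves alike on the core of compound 2.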